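A Nitro Group on Compound 3

The source may hold more compounds than are shown below. What is called first, only, known or untested is meant among the compounds shown, and "the series" means these compounds.

In a functional assay on SGC-7901 cells (Homo sapiens) for antiproliferative activity, read by MTT assay, with a stated time of 72 h (on this read-out lower numbers stand for stronger inhibition and higher numbers for weaker inhibition), compound 1 `COc1ccc(-c2ssc(=S)c2-c2cc(OC)c(OC)c(OC)c2)cc1` gives 21100 nM and compound 2 `COc1ccc(-c2ssc(=S)c2-c2cc(OC)c(OC)c(OC)c2)cc1N` gives 444 nM while compound 3 `COc1ccc(-c2ssc(=O)c2-c2cc(OC)c(OC)c(OC)c2)cc1` gives 134 nM as the lowest of the three numbers. Compound 3 is therefore the most potent of the measured set, with both gaps to the others lying beyond the scatter.

The next structure is compound 4 `COc1ccc(-c2ssc(=O)c2-c2cc(OC)c(OC)c(OC)c2)cc1[N+](=O)[O-]` which alters compound 3 in one place: nitro in place of hydrogen on an aromatic carbon with the new group ortho to a methoxy group and meta to a large group.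

Within the data shown here, only one measured step bears on this change. Amino in place of hydrogen on an aromatic carbon gave a 48-fold lower number from compound 1 to compound 2 (1.68 log units; beyond the scatter) as a large improvement. That step is a weak guide, since it introduced amino rather than nitro and started from the core of compound 1 rather than that of compound 3. Among the measured compounds shown here, no measured compound carries a nitro group. For the measured compounds named here, with compound 3 already at 134 nM and no direct precedent, a repeat of that large fall is not expected, and a modest rise in the number seems more likely.

The expected change is a 2.2-fold higher number from compound 3 to compound 4 (0.35 log units; beyond the scatter) and remains uncertain in size. For compound 4 the estimated value is 300 nM with an expected range from 40 nM to 2500 nM in this assay when tested.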

Compound 4, half-maximal inhibitory concentration: 440 nM
Beside the measured number, compound 4's estimate is 1.5-fold (0.17 log units) below it; the measured number falls inside the stated range.
By their numbers in this assay, from the lowest: compound 3; then compounds 4 and 2 (each within the scatter of the next); then compound 1.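

In this assay, nitro in place of hydrogen on an aromatic carbon gives a 3.3-fold higher number from compound 3 to compound 4 (0.52 log units; beyond the scatter) on the core of compound 3, so this place on the ring, ortho to a methoxy group, can hold a nitro group at a modest cost in potency. Among these compounds, the only earlier change at this place, which gave a 48-fold lower number from compound 1 to compound 2 (1.68 log units; beyond the scatter) on the core of compound 1, ran in the opposite direction, so a new group here does not always lower the number, and the two steps together show that the outcome varies with the group, the core or both. The data offer no measurement that explains why the number rises with the nitro group here.

The two steps differ in both the entering group and the core, so an amino group on the core of compound 3, or a nitro group on the core of compound 1, would be needed to separate those two influences. As far as these compounds go, whether a smaller entering group such as fluorine, or a hydroxyl group, would keep the number of compound 3 or move it in either direction also remains open.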